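The source may report more compounds than this note shows. Statements on the series, on what has been measured and on what is new or still open speak of the compounds shown alone.

Three measured compounds share one core and were tested in an ADME assay on HEK293 cells (Homo sapiens) for cytotoxicity, read by MTT assay, with a stated time of 48 h; on this read-out lower numbers stand for stronger inhibition and higher numbers for weaker inhibition. Compound 1 `CN(c1ccc(NC(=O)c2ccc(C(F)(F)F)cc2C(F)(F)F)cc1OCc1ccccc1C(F)(F)F)S(C)(=O)=O` gives > 500000 nM, which is a limit of the assay rather than a number. Compound 2 `CCCCCCOc1cc(NC(=O)c2ccc(C(F)(F)F)cc2C(F)(F)F)ccc1N(C)S(C)(=O)=O` gives > 500000 nM, again a limit. Compound 3 `CN(c1ccc(NC(=O)c2cc(C(F)(F)F)cc(C(F)(F)F)c2)cc1OCc1ccccc1C(F)(F)F)S(=O)(=O)Cc1ccccc1` gives > 500000 nM, also a limit. Compound 2 differs from compound 1 by pentyl in place of 2-(trifluoromethyl)phenyl on a saturated chain carbon bound to an oxygen on an aromatic ring, and the size of the resulting step, a step that the two limits leave unreadable from compound 1 to compound 2, cannot be read because of the limit of > 500000 nM in this assay, at which 3 of the 3 values shown sit. How the core of compound 3 differs from that of compound 1 is not broken down here. Compound 4 `CCCCCCOc1cc(NC(=O)c2cc(C(F)(F)F)cc(C(F)(F)F)c2)ccc1N(C)S(=O)(=O)Cc1ccccc1`, not yet measured, carries the same change as that pair, (pentyl in place of 2-(trifluoromethyl)phenyl on a saturated chain carbon bound to an oxygen on an aromatic ring), on the core of compound 3. The expected step is a step that the limit leaves unreadable from compound 3 to compound 4, resting on (the limit of > 500000 nM in this assay, at which 3 of the 3 values shown sit). Compound 4 is therefore estimated at 600000 nM, between 250000 nM and 2000000 nM, most likely reported as a limit once more.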

Compound 4, half-maximal inhibitory concentration: 69900 nM
For compound 4 the middle estimate is 8.6-fold (0.93 log units) above the measured one; measured number outside the range, below it.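

In this assay, putting pentyl in place of 2-(trifluoromethyl)phenyl on the core of compound 3 gives an at least 7.1-fold lower number from compound 3 to compound 4 (0.85 log units; beyond the scatter), so on this core the change does increase cytotoxicity. This is a minimum size, not an exact one, since compound 3 has only a limit. The same change on the core of compound 1 cannot be read, so these data do not show whether the effect carries from one core to the other: the limit of > 500000 nM in this assay, at which 3 of the 4 values shown sit.

As far as these compounds go, it remains open whether the pentyl group would lower the number on the core of compound 1 as well. How a longer chain or a carboxylic acid in place of pentyl would read on either core is also unknown.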